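The compounds below may be only part of what the source reports. "The series", "measured", "known", "first", "only" and "open" are said of these compounds alone.

Three compounds that differ only in the substituted phenyl group on the chain carbon have so far been tested in a functional assay on CCRF-CEM cells (Homo sapiens) for antiproliferative activity, with a stated time of 72 h; a higher number here means a weaker inhibitor, a lower number a stronger inhibitor. In this assay, compound 1 `OC[C@H]1O[C@@H](n2cnc3c(NCc4ccccc4F)ncnc32)[C@H](O)[C@@H]1O` gives 4600 nM, compound 2 `OC[C@H]1O[C@@H](n2cnc3c(NCc4cccc(Br)c4)ncnc32)[C@H](O)[C@@H]1O` gives 5000 nM, and compound 3 `COc1ccccc1CNc1ncnc2c1ncn2[C@@H]1O[C@H](CO)[C@@H](O)[C@H]1O` gives 3200 nM. Compound 3 therefore cannot be told apart from the other two, since its gap to each lies within the usual scatter of repeated measurements.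

The next compound, compound 4 `COc1cccc(CNc2ncnc3c2ncn3[C@@H]2O[C@H](CO)[C@@H](O)[C@H]2O)c1`, has the same atoms as compound 3, joined differently: 3-methoxyphenyl in place of 2-methoxyphenyl on a saturated chain carbon bound to a nitrogen on an aromatic ring. Put simply, it carries 3-methoxyphenyl in place of 2-methoxyphenyl on a saturated chain carbon bound to a nitrogen on an aromatic ring.

Among the compounds with values here, no measured step makes exactly this change, but three related ones offer guidance. Replacing 2-fluorophenyl with 3-bromophenyl gives a 1.1-fold higher number from compound 1 to compound 2 (0.04 log units; within the scatter). Replacing fluoro with methoxy gives a 1.4-fold lower number from compound 1 to compound 3 (0.16 log units; within the scatter). Replacing 3-bromophenyl with 2-methoxyphenyl gives a 1.6-fold lower number from compound 2 to compound 3 (0.19 log units; within the scatter). None of these small steps offers a firm direction, so no change beyond the scatter is expected here, and the expected shift is only a 1.3-fold higher number from compound 3 to compound 4 (0.10 log units; within the scatter). For compound 4, the estimated value is 4000 nM, with an expected range from 2000 nM to 8000 nM.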

Compound 4, half-maximal inhibitory concentration: 7600 nM
Estimate against measurement, compound 4: 1.9-fold (0.28 log units) below; measured number inside the range.
By their numbers in this assay, from the lowest: compounds 3, 1, 2 and 4 (each within the scatter of the next, the first and the last beyond it).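

Moving the methoxy group, with 3-methoxyphenyl in place of 2-methoxyphenyl on a saturated chain carbon bound to a nitrogen on an aromatic ring, gives a 2.4-fold higher number from compound 3 to compound 4 (0.38 log units; beyond the scatter) in this assay. Within the data shown here, this is the first step to lie beyond the scatter, and it comes from a change in how the same atoms are joined, so the placement of the methoxy group on the aromatic ring can matter even when the group itself stays the same. Among these compounds, the other two new steps, a 1.5-fold higher number from compound 2 to compound 4 (0.18 log units; within the scatter) and a 1.7-fold higher number from compound 1 to compound 4 (0.22 log units; within the scatter), stay within the scatter, so only the pair of methoxy compounds stands clearly apart, and no measurement available here offers a reason for that gap.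

Methoxy is the only substituent seen in both placements, so it remains open whether fluoro or bromo would show a similar gap if moved, with 3-fluorophenyl or 2-bromophenyl as the direct tests. Going by these compounds, it is also open how an amine or a hydroxyl in place of the methoxy group, or a longer chain joining the aromatic ring to the nitrogen, would behave in this assay.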